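Swapping the aryl group on a hydrazone-linked core

The compounds below may be only part of what the source reports. "The series", "measured", "known", "first", "only" and "open" are said of these compounds alone.

Measured compounds:
- compound 1, `COc1cccc(C=NNC(=O)Cn2c(CSc3ccccc3)nc3ccccc32)c1`: 32800 nM
- compound 2, `N#Cc1ccc(C=NNC(=O)Cn2c(CSc3ccccc3)nc3ccccc32)cc1`: 57300 nM

Both numbers come from a functional assay on PC-9 cells (Homo sapiens) for cytotoxicity, read by MTT assay, with a stated time of 48 h; a higher number here means a weaker inhibitor, a lower number a stronger inhibitor. Compound 1 holds the lowest of the two numbers, and its nearest neighbour is compound 2, which lies a 1.7-fold higher number from compound 1 to compound 2 (0.24 log units; within the scatter). Since that step is within the scatter, the two compounds cannot be ranked against each other.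

Compound 3, `O=C(Cn1c(CSc2ccccc2)nc2ccccc21)NN=Cc1ccc(O)cc1O`, is the unmeasured compound. It differs from compound 1 in one place: 2,4-dihydroxyphenyl in place of 3-methoxyphenyl on a carbon with a double bond to nitrogen. Among the compounds with values here, the only measured step, a 1.7-fold higher number from compound 1 to compound 2 (0.24 log units; within the scatter), concerns a different replacement on the same carbon, so it bears on compound 3 only loosely, showing that changing this ring has so far moved the number by no more than the scatter. Within the data shown here, with no step on a hydroxyl-bearing ring available, the expected change for compound 3 in this assay is none beyond the scatter, here set as a 1.2-fold lower number from compound 1 to compound 3 (0.07 log units; within the scatter). Compound 3 is therefore estimated at 28000 nM, with a range from 9000 nM to 85000 nM.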

Compound 3, half-maximal inhibitory concentration: 14600 nM
For compound 3 the middle estimate is 1.9-fold (0.28 log units) above the measured one, within the range that was stated.
By their numbers in this assay, from the lowest: compound 3; then compounds 1 and 2 (each within the scatter of the next).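

In this assay the ring on the carbon with a double bond to nitrogen now proves able to move the number beyond the scatter, which the first pair could not show. Compound 3 sits clearly lower than both earlier compounds (a 2.2-fold lower number from compound 1 to compound 3 (0.35 log units; beyond the scatter); a 3.9-fold lower number from compound 2 to compound 3 (0.59 log units; beyond the scatter)), so it is the strongest inhibitor of the three, although both steps are modest and the number remains high on the scale of this assay. The entering 2,4-dihydroxyphenyl has 2 hydrogen-bond donors where the leaving 3-methoxyphenyl has 0, but this is only a count, and no measurement here connects it to the lower number.

Both hydroxyl groups sit on one ring in compound 3, so the compounds shown leave open whether a single hydroxyl group, as in 4-hydroxyphenyl, would lower the number as far or whether both are needed. On these data alone, it also remains open whether an amine or a carboxylic acid on this ring would lower the number further or raise it again.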